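This account rests on a few compounds, and the source may have more. Where it says the series, first, only, none or still open, it means among the compounds named here.

Working notes on the series. In a functional assay on HL-60 cells (Homo sapiens) for cytotoxicity, read by CCK-8 assay, with a stated time of 72 h (a lower number here means a stronger inhibitor, a higher number a weaker inhibitor), compound 1 `CC(C)(C)OC(=O)/C=C1/C(=O)Nc2ccccc21` gives 2450 nM, the lowest of the three numbers to hand. Compound 2 `CN1C(=O)/C(=C/C(=O)OC(C)(C)C)c2ccccc21` gives 2760 nM in this assay, and compound 3 `COc1cccc2c1NC(=O)/C2=C/C(=O)OC(C)(C)C` gives 9680 nM. Compound 4 `CC(C)(C)OC(=O)/C=C1/C(=O)Nc2ccc([N+](=O)[O-])cc21` has not yet been measured; it differs from compound 1 by nitro in place of hydrogen on an aromatic carbon. Going by the values given here, two measured steps bear on this. The change on the ring nitrogen, a 1.1-fold higher number from compound 1 to compound 2 (0.05 log units; within the scatter), stays within the scatter and says little. The other change on the aromatic ring, a 4.0-fold higher number from compound 1 to compound 3 (0.60 log units; beyond the scatter), is the closer precedent, though it concerns a different group. The expected step, a 1.8-fold higher number from compound 1 to compound 4 (0.26 log units; within the scatter), is accordingly a modest loss. Compound 4 is therefore estimated at 4500 nM, within a range from 1500 nM to 14000 nM.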

Compound 4, half-maximal inhibitory concentration: 9860 nM
Compound 4: middle estimate off by 2.2-fold (0.34 log units), on the low side; the measured number falls inside the stated range.
By their numbers in this assay, from the lowest: compounds 1 and 2 (each within the scatter of the next); then compounds 3 and 4 (each within the scatter of the next).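

In this assay, nitro on this aromatic carbon, meta to a fused ring and para to a fused ring, gives a weaker number, a 4.0-fold higher number from compound 1 to compound 4 (0.60 log units; beyond the scatter), beyond the scatter. This step matches in printed size the methoxy step, a 4.0-fold higher number from compound 1 to compound 3 (0.60 log units; beyond the scatter), so both aromatic substituents shown weaken the number, although they do not share one carbon, and this is the first group shown at this position. No evidence on the cause is at hand. Going by these compounds, whether an amine or a carboxylic acid on this same carbon would give a similar loss remains open. So does whether methoxy here would match nitro.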